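The compounds below may be only part of what the source reports. "The series", "measured", "known", "first", "only" and "open" are said of these compounds alone.

Among the compounds with values here, compound 2 `Cc1ccc(-c2cs/c(=N/NC(=O)CSc3nnnn3C)n2-c2ccccc2)cc1` gives 44.3% in a functional assay on C6 cells (Rattus norvegicus) for cytotoxicity, read by MTT assay, with a stated time of 24 h, tested at 50 ug/mL (a higher number here means a weaker effect of the compound at the concentration tested, a lower number a stronger effect), the second highest of the three numbers measured so far. Compound 1 `Cc1ccc(-c2cs/c(=N/NC(=O)CSc3nnnn3-c3ccccc3)n2-c2ccccc2)cc1` gives 29.5% in this assay, and compound 3 `Cn1nnnc1SCC(=O)N/N=c1/scc(-c2ccc([N+](=O)[O-])cc2)n1-c1ccccc1` gives 69.2% in this assay. Two steps are known within the set: a number 14.8 percentage points higher from compound 1 to compound 2 (beyond the scatter), with methyl in place of phenyl on an aromatic nitrogen, and a number 24.9 percentage points higher from compound 2 to compound 3 (beyond the scatter), with nitro in place of methyl on an aromatic carbon. Compound 4 `Cc1ccc(-c2cs/c(=N/NC(=O)CSc3ncccn3)n2-c2ccccc2)cc1` differs from compound 2 in the group carried on the sulfur: pyrimidin-2-yl in place of 1-methyl-1H-tetrazol-5-yl on a sulfur. Neither measured step alters what sits on that sulfur, so neither bears directly on this change. The nearest comparison is the step from compound 1 to compound 2, which touched only the substituent on the 1-methyl-1H-tetrazol-5-yl ring and moved the read-out modestly. Within the data shown here, with no closer precedent, the step to compound 4 is expected to be small or within the scatter, in either direction. For compound 4 a value of 45% is expected in this assay, with a range from 25% to 65%. The expected step is therefore a number 0.7 percentage points higher from compound 2 to compound 4 (within the scatter).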

Compound 4, a percentage reported as activity, at one concentration (the size of the read-out at that concentration, not a potency): 64.4%
For compound 4 the middle estimate is 19.4 percentage points below the measured one; the range from low to high includes it.
By their numbers in this assay, from the lowest: compound 1; then compound 2; then compounds 4 and 3 (each within the scatter of the next).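

In this assay, within the data shown here, the group on the sulfur, which no earlier step touched, proves able to move the read-out: a number 20.1 percentage points higher from compound 2 to compound 4 (beyond the scatter) with pyrimidin-2-yl in place of 1-methyl-1H-tetrazol-5-yl, and a number 34.9 percentage points higher from compound 1 to compound 4 (beyond the scatter) with pyrimidin-2-yl in place of 1-phenyl-1H-tetrazol-5-yl. Both tetrazole-bearing compounds therefore show a stronger effect at the tested concentration than the pyrimidine-bearing compound 4, with no compound shown going against this for the change on the sulfur. No measured evidence accounts for this difference.

Still open, from the compounds shown here alone, is how a non-aromatic group on the sulfur, such as a chain ending in an amine or a carboxylic acid, would compare with these rings. Also open, going by these compounds, is whether pyrimidin-2-yl has the same effect when nitro stands in place of methyl on the aromatic carbon.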